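From butoxy to fluoro in an antiproliferative series

The source may report more compounds than this note shows. Statements on the series, on what has been measured and on what is new or still open speak of the compounds shown alone.

Values so far in a functional assay on SGC-7901 cells (Homo sapiens) for antiproliferative activity, read by MTT assay, with a stated time of 24 h (a higher number here means a weaker inhibitor, a lower number a stronger inhibitor), are as follows.
Compound 1 (`Cc1ccccc1NNC(=O)c1cccc(NS(=O)(=O)c2cnc(O)nc2O)c1`) gives > 20000 nM as a limit of the assay
Compound 2 (`O=C(NNc1cccc(Cl)c1)c1cccc(NS(=O)(=O)c2cnc(O)nc2O)c1`) gives 11800 nM as a measured number
Compound 3 (`CCCCOc1ccc(C(=O)NNC(=O)c2cccc(NS(=O)(=O)c3cnc(O)nc3O)c2)cc1`) gives 7370 nM as a measured number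
Compound 4 (`O=C(NNC(=O)c1cccc(NS(=O)(=O)c2cnc(O)nc2O)c1)c1ccc(F)cc1`) has not yet been measured

In this assay compound 3 gives 7370 nM and lies within the scatter of its nearest neighbour, compound 2 at 11800 nM in the same read-out, so the two cannot be ranked. Compound 1 is known only by the limit > 20000 nM of that assay.

The change now in question is fluoro in place of butoxy on an aromatic carbon with fluoro in place of butoxy on an aromatic carbon, para to a large group, so that 4-butoxyphenyl becomes 4-fluorophenyl. For the measured compounds named here, the one measured step is an at least 1.6-fold lower number from compound 1 to compound 2 (0.22 log units; that floor lies within the scatter) and it concerns another change, 3-chlorophenyl in place of 2-methylphenyl on an amine nitrogen. It never touches the butoxy group and offers only weak guidance here.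

No step beyond the scatter is therefore expected in this assay although a drift toward a higher number seems the likelier direction. A result reported only as a limit would not be surprising. The estimated change is a 1.4-fold higher number from compound 3 to compound 4 (0.13 log units; within the scatter) and it stays small. Compound 4 is estimated at 10000 nM with an expected range from 4500 nM to 20000 nM in this read-out.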

Compound 4, half-maximal inhibitory concentration: > 20000 nM
Compound 4 was reported as a limit; the forecaster's own chance of this, stated with the estimate: 25%; middle value at least 2.0-fold (0.30 log units) away from the limit.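

In this assay, the group para to a large group on this aromatic ring is not a silent position: fluoro in place of butoxy gives an at least 2.7-fold higher number from compound 3 to compound 4 (0.43 log units; beyond the scatter), the only step among these compounds that is printed as beyond the scatter. The other readable change, (4-fluorophenyl)carbonyl in place of 3-chlorophenyl on an amine nitrogen, gives an at least 1.6-fold higher number from compound 2 to compound 4 (0.22 log units; that floor lies within the scatter), so its floor fixes no order between those two compounds. The step from compound 1 to compound 4 cannot be read, and the full size of the loss on going from 4-butoxyphenyl to 4-fluorophenyl stays unknown, since both of those compounds stand at a limit rather than at a number: the limit of > 20000 nM in this assay, at which 2 of the 4 values shown sit.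

The compounds shown leave open whether the chain or the ether oxygen of butoxy carries the difference, which a plain butyl group would help to separate. They also leave open how the value moves along a series of methoxy, ethoxy and longer alkoxy chains such as hexyloxy at this same place.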